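A few compounds are considered here, and "the series" means these few. Any claim that something is new, unique, unknown or untested is made for them only; others in the source may bear on it.

Three compounds of the shared core have numbers in a functional assay on SK-OV-3 cells (Homo sapiens) for antiproliferative activity, read by MTT assay, with a stated time of 72 h; on this read-out lower numbers stand for stronger inhibition and higher numbers for weaker inhibition. Compound 1 `O=C(CCc1cccc2c1B(O)OC2)Nc1ccc(I)cc1` gives 51000 nM. Compound 2 `CC(C)(C)OC(=O)Nc1ccc(NC(=O)CCc2cccc3c2B(O)OC3)cc1` reaches only the limit of the assay, > 100000 nM, so no number is known for it. Compound 3 `O=C(CCc1cccc2c1B(O)OC2)Nc1cccc(-c2cccc(F)c2)c1` gives 480 nM, the lowest of the two numbers; its nearest neighbour is compound 1, a gap well beyond the scatter. For the measured compounds named here, the one measured step, an at least 1.9-fold higher number from compound 1 to compound 2 (0.29 log units; that floor lies within the scatter), has its floor inside the scatter and concerns the aryl substituent of the anilide, not the biphenyl end present in compound 3, so it offers no direct guide. Going by the values given here, the only evidence on a cause is the limit of > 100000 nM in this assay, at which 1 of the 3 values shown sits, which says nothing of the present change.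

Compound 4 `N#Cc1cccc(-c2cccc(NC(=O)CCc3cccc4c3B(O)OC4)c2)c1` differs from compound 3 as follows: cyano in place of fluoro on an aromatic carbon

Among the compounds with values here, no measured step bears on this change. The expectation for compound 4 is therefore a step of a 1.3-fold higher number from compound 3 to compound 4 (0.10 log units; within the scatter) in this assay, that is, nothing beyond the scatter. Compound 4 is estimated at 600 nM, with a range from 200 nM to 2000 nM.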

Compound 4, half-maximal inhibitory concentration: 120 nM
For compound 4 the middle estimate is 5.0-fold (0.70 log units) above the measured one, outside the stated range (below it).
By their numbers in this assay, from the lowest: compound 4; then compound 3; then compound 1. At a limit, above all of these: compound 2.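

In this assay, the change from 3-fluorophenyl to 3-cyanophenyl gives a 4.0-fold lower number from compound 3 to compound 4 (0.60 log units; beyond the scatter) as a step beyond the scatter, so the group at this place, on an aromatic carbon meta to a large group, influences the read-out. For the compounds shown here, the earlier compounds offered no step at this place, and the only step among them concerned the aryl substituent of the anilide, with its floor inside the scatter. The data shown offer nothing that explains this step.

On these data alone, whether a primary amide, a carboxylic acid or an amine at this place would lower the number further remains open. Also open, as far as these compounds go, is whether the same step would appear with other groups elsewhere on the shared core, since a single pair defines it and no trend can be drawn from it.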